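The compounds below may be only part of what the source reports. "The series", "measured", "known", "first", "only" and "open" are said of these compounds alone.

Measured compounds:
compound 1 `Cc1c(Cc2ccccc2)c(=O)oc2cc(OCC(O)CNc3nccs3)ccc12`: 93000 nM
compound 2 `Cc1c(Cc2ccc(F)cc2)c(=O)oc2cc(OCC(O)CN3CCC(C(N)=O)CC3)ccc12`: 89300 nM
compound 3 `CC(=O)C1CCN(CC(O)COc2ccc3c(C)c(Cc4cccc([N+](=O)[O-])c4)c(=O)oc3c2)CC1`: 90500 nM

The series shares one core and varies the group on the saturated chain carbon bound to an aromatic carbon, and the amine at the far end of the hydroxypropoxy chain. In an ADME assay on A549 cells (Homo sapiens) for cytotoxicity, read by CellTiter-Glo (on this read-out higher numbers stand for lower toxicity in this test and lower numbers for higher toxicity in this test), compound 1 gives 93000 nM, compound 2 gives 89300 nM and compound 3 gives 90500 nM. These three numbers sit within the usual scatter of one another, so no order can be read among them; compound 2 stands in the same band as compound 1 and compound 3, and nothing in the numbers separates it from either.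

Compound 4 `Cc1c(Cc2cccc3ccccc23)c(=O)oc2cc(OCC(O)CN3CCC(C(N)=O)CC3)ccc12` is not yet measured. It differs from compound 2 in one place: naphthalen-1-yl in place of 4-fluorophenyl on a saturated chain carbon bound to an aromatic carbon. Across compound 1, compound 2 and compound 3 the group on that chain carbon changes without the number in this assay moving beyond the scatter, so the expectation for compound 4 is a step of no size beyond the scatter in this assay, in no particular direction.

On that basis compound 4 is expected to give about 85000 nM in this assay, with a range from 40000 nM to 180000 nM. The step this estimate implies, a 1.1-fold lower number from compound 2 to compound 4 (0.02 log units; within the scatter), is expected to stay inside the scatter.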

Compound 4, half-maximal cytotoxic concentration: 42400 nM
The estimate for compound 4 lay 2.0-fold (0.30 log units) above the measured number, within the range that was stated.
By their numbers in this assay, from the lowest: compound 4; then compounds 2, 3 and 1 (each within the scatter of the next).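

In this assay, the group on a saturated chain carbon bound to an aromatic carbon now shows an effect on the number: naphthalen-1-yl in place of 4-fluorophenyl gives a 2.1-fold lower number from compound 2 to compound 4 (0.32 log units; beyond the scatter), a modest step. The amine at the far end of the hydroxypropoxy chain is the same in both compounds, so the step belongs to this one change, though that change adds a second six-membered aromatic ring and removes the fluorine together. Nothing measured here explains why the number moves.

The data do not separate the added ring from the lost fluorine, nor do they show whether the attachment point on the naphthalene matters; naphthalen-2-yl or 4-chlorophenyl on the same chain carbon, with the amine unchanged, would speak to these questions. As far as these compounds go, it also remains open whether the step of compound 4 carries over to other amines at the end of the chain, such as a morpholine.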